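The source may hold more compounds than are shown below. What is called first, only, known or untested is meant among the compounds shown, and "the series" means these compounds.

Compound 1 `CN(C)c1cccc(Nc2nccc(-c3cccnc3)n2)c1`: 1800 nM
Compound 2 `Cc1ccc(Nc2nccc(-c3ccccn3)n2)cc1C`: 5900 nM
Compound 3 `CN(C)c1cccc(Nc2nccc(-c3ccccn3)n2)c1`: 400 nM

In a functional assay for inhibition, with Homo sapiens as the target (on this read-out higher numbers stand for weaker inhibition and lower numbers for stronger inhibition), compound 1 stands second highest of these three numbers. Among the measured compounds shown here, compound 2 gives the higher number of the two, and no single-point step links it to compound 1. Compound 3 is the furthest, with a 4.5-fold lower number from compound 1 to compound 3 (0.65 log units; beyond the scatter) after a change on the shared core. Compound 4 `CC(=O)c1cccc(Nc2nccc(-c3cccnc3)n2)c1` differs from compound 1 in one place: acetyl in place of dimethylamino on an aromatic carbon. For the measured compounds named here, none of the measured steps involves this position, so nothing measured bears on it directly, and the expected outcome in this assay is a step of no size beyond the scatter in either direction. The estimate for compound 4 is therefore 2000 nM (range 600 nM to 6500 nM), meaning an expected 1.1-fold higher number from compound 1 to compound 4 (0.05 log units; within the scatter).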

Compound 4, half-maximal inhibitory concentration: 4100 nM
For compound 4 the middle estimate is 2.1-fold (0.31 log units) below the measured one, within the range that was stated.
By their numbers in this assay, from the lowest: compound 3; then compound 1; then compounds 4 and 2 (each within the scatter of the next).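

The position held by dimethylamino on the aromatic ring is sensitive to change: in this assay, acetyl there gives a 2.3-fold higher number from compound 1 to compound 4 (0.36 log units; beyond the scatter) on the shared core. The two groups have equal counts of heavy atoms and hydrogen-bond acceptors, so those counts alone do not set the number here. Nothing available explains the step.

Going by these compounds, how a primary amine or a carboxylic acid at this place would compare remains open. So does whether acetyl would have a similar effect alongside the pyridin-2-yl of compound 3.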